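The source may report more compounds than this note shows. Statements on the series, on what has been measured and on what is new or still open speak of the compounds shown alone.

Working notes on the series. Compound 2 `CN1C[C@H](C(=O)Nc2ccc(C#N)cc2)[C@@H](c2ccc(/C=C/C(=O)Nc3ccccc3N)cc2)C1` gives 35 mL/min/kg in an in vitro ADME assay on microsomes from liver (Mus musculus) for pharmacokinetics, read by LC-MS, with a stated time of 10 min, tested at 1 uM; a higher number here means faster removal of the compound, a lower number slower removal. Compound 1 `CN1C[C@H](C(=O)Nc2ccccc2)[C@@H](c2ccc(/C=C/C(=O)Nc3ccccc3N)cc2)C1` gives 67 mL/min/kg, and compound 3 `CN1C[C@H](C(=O)Nc2cccc(Cl)c2)[C@@H](c2ccc(/C=C/C(=O)Nc3ccccc3N)cc2)C1` gives 58 mL/min/kg. Compound 2 stands at the low edge of these three numbers, but the gap to compound 3, a 1.7-fold higher number from compound 2 to compound 3 (0.22 log units; within the scatter), and the gap to compound 1, read as a 1.9-fold lower number from compound 1 to compound 2 (0.28 log units; within the scatter), both fall within the scatter, so the three compounds are not separated in this assay. The remaining step, a 1.2-fold lower number from compound 1 to compound 3 (0.06 log units; within the scatter), is also within the scatter.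

Compound 4 `COc1cccc(NC(=O)[C@H]2CN(C)C[C@@H]2c2ccc(/C=C/C(=O)Nc3ccccc3N)cc2)c1` differs from compound 2 as follows: 3-methoxyphenyl in place of 4-cyanophenyl on an amide-type nitrogen. The step that bears most directly on this change is the one at the same amide-type nitrogen, a 1.7-fold higher number from compound 2 to compound 3 (0.22 log units; within the scatter), which exchanged one substituted phenyl for another and stayed within the scatter. The step from the unsubstituted phenyl of compound 1 to the cyano-bearing phenyl of compound 2, a 1.9-fold lower number from compound 1 to compound 2 (0.28 log units; within the scatter), was also within the scatter. Because a 1.7-fold higher number from compound 2 to compound 3 (0.22 log units; within the scatter) was small, the expected step for compound 4 is small as well, leaning toward a higher number: a 1.6-fold higher number from compound 2 to compound 4 (0.20 log units; within the scatter). Compound 4 is therefore estimated at 55 mL/min/kg, with a range of 30 mL/min/kg to 100 mL/min/kg.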

Compound 4, clearance: 65 mL/min/kg
The estimate for compound 4 lay 1.2-fold (0.07 log units) below the measured number; the measured number falls inside the stated range.
By their numbers in this assay, from the lowest: compounds 2, 3, 4 and 1 (each within the scatter of the next).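

In this assay the 3-methoxyphenyl on the amide-type nitrogen does not separate compound 4 from any other compound: a 1.9-fold higher number from compound 2 to compound 4 (0.27 log units; within the scatter) and a 1.1-fold higher number from compound 3 to compound 4 (0.05 log units; within the scatter) and a 1.0-fold lower number from compound 1 to compound 4 (0.01 log units; within the scatter) all stay within the scatter. Among the compounds shown here, the series now holds four different aryl groups at this nitrogen (phenyl, 4-cyanophenyl, 3-chlorophenyl and 3-methoxyphenyl), and no step among them lies beyond the scatter. No measurement is at hand that could account for these numbers.

Going by these compounds, whether an amine, a carboxylic acid or a longer alkoxy chain on this phenyl would give a step beyond the scatter remains open. Each substituent also appears in a single placement on the phenyl, so placement cannot be told apart from the identity of the group.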